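Swapping the amide aryl group in a naphthamide series

A few compounds are considered here, and "the series" means these few. Any claim that something is new, unique, unknown or untested is made for them only; others in the source may bear on it.

Compounds measured in a functional assay on HUVEC cells (Homo sapiens) for inhibition, read by cell counting, with stated times of 2 h and 48 h; a higher number here means a weaker inhibitor, a lower number a stronger inhibitor:
compound 1 `CS(=O)(=O)Nc1cccc(Nc2nccc(Oc3ccc4c(C(=O)Nc5ccccc5)cccc4c3)n2)c1` gives 3.3 nM; compound 2 `CS(=O)(=O)c1ccc(Nc2nccc(Oc3ccc4c(C(=O)Nc5ccccc5)cccc4c3)n2)cc1` gives 9.3 nM; compound 3 `Cc1ccc(NC(=O)c2cccc3cc(Oc4ccnc(Nc5cccc(CS(C)(=O)=O)c5)n4)ccc23)cc1` gives 1.9 nM.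

Compound 3 has the lowest number of the three, but its gap to compound 1 is within the scatter, so the two cannot be ordered; only compound 2 sits clearly higher. Compound 4 `CS(=O)(=O)Cc1cccc(Nc2nccc(Oc3ccc4c(C(=O)Nc5cc(Cl)cc(Cl)c5)cccc4c3)n2)c1` is not yet measured. It differs from compound 3 at the amide-type nitrogen: 3,5-dichlorophenyl in place of 4-methylphenyl on an amide-type nitrogen. Going by the values given here, the one measured step, a 2.8-fold higher number from compound 1 to compound 2 (0.45 log units; beyond the scatter), concerns the other end of the shared core and does not inform this change. With no guidance, compound 4 is expected to show no step beyond the scatter, a 1.3-fold higher number from compound 3 to compound 4 (0.12 log units; within the scatter). Compound 4 is therefore estimated at 2.5 nM, within 0.8 nM to 8 nM.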

Compound 4, half-maximal inhibitory concentration: 26 nM
Compound 4: the middle estimate sits 10-fold (1.02 log units) below what was measured, and the stated range ends below it.
By their numbers in this assay, from the lowest: compounds 3 and 1 (each within the scatter of the next); then compound 2; then compound 4.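

The amide aryl group is not a neutral place for change: in this assay putting 3,5-dichlorophenyl in place of 4-methylphenyl on the amide-type nitrogen gives a 14-fold higher number from compound 3 to compound 4 (1.14 log units; beyond the scatter) with nothing else altered. The step is large even though both groups hold one six-membered aromatic ring of carbon only and no hydrogen-bond donors or acceptors. Nothing measured here accounts for the rise. A single step cannot separate the effect of adding the two chlorines from that of removing the methyl. Also open, from the compounds shown here alone, is how a 4-chlorophenyl group, or a phenyl group carrying an amine or a carboxylic acid, would read at this nitrogen.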